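The source may hold more compounds than are shown below. What is called first, only, known or untested is meant among the compounds shown, and "the series" means these compounds.

Within the data shown here, three related compounds have numbers so far in a functional assay on MCF7 cells (Homo sapiens) for antiproliferative activity, read by MTT assay, with a stated time of 48 h; on this read-out higher numbers stand for weaker inhibition and lower numbers for stronger inhibition. Here compound 1 `COc1ccc2c(/C=C/C(=O)c3cc(N)c(OC)c(OC)c3)c[nH]c2c1` gives 249 nM and compound 2 `COc1cc(C(=O)/C=C/c2c[nH]c3ccccc23)cc(SC)c1OC` gives 186 nM in this test. Compound 3 `COc1cc(C(=O)/C=C/c2cn(C)c3ccccc23)cc(N)c1OC` gives 631 nM as the highest number of the three, which makes it the weakest inhibitor, with both gaps beyond the usual scatter.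

Compound 4 `COc1cc(C(=O)/C=C/c2c[nH]c3ccccc23)cc(N)c1OC` has not been measured yet. It differs from compound 3 in one place: hydrogen in place of methyl on an aromatic nitrogen. Among the measured compounds shown here, no measured pair shows this change alone, so the expected step can only be judged indirectly. Compound 1 at 249 nM and compound 2 at 186 nM both carry hydrogen on that nitrogen and both have lower numbers than compound 3, although each also differs from it elsewhere. A moderate move towards stronger inhibition, beyond the scatter, is therefore expected, as the estimated step of a 2.6-fold lower number from compound 3 to compound 4 (0.42 log units; beyond the scatter) shows. Compound 4 is estimated at 240 nM, within an expected range of 90 nM to 600 nM.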

Compound 4, half-maximal inhibitory concentration: 595 nM
For compound 4 the middle estimate is 2.5-fold (0.39 log units) below the measured one; the range from low to high includes it.
By their numbers in this assay, from the lowest: compounds 2 and 1 (each within the scatter of the next); then compounds 4 and 3 (each within the scatter of the next).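

In this assay, among these compounds, this is the first direct reading of hydrogen in place of methyl on the aromatic nitrogen, and the change alone moves the number by very little (a 1.1-fold lower number from compound 3 to compound 4 (0.03 log units; within the scatter)), so at this position the two cannot be told apart. The lower numbers of compound 1 and compound 2 therefore do not come from the hydrogen on that nitrogen, since compound 4 carries it too: the steps that count are amino in place of methylsulfanyl on an aromatic carbon (a 3.2-fold higher number from compound 2 to compound 4 (0.51 log units; beyond the scatter)) and hydrogen in place of methoxy on an aromatic carbon (a 2.4-fold higher number from compound 1 to compound 4 (0.38 log units; beyond the scatter)). Nothing available explains any of these steps.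

As far as these compounds go, whether a longer chain such as ethyl, or a benzyl group, on that nitrogen would leave the number equally unchanged stays open. So does whether methyl and hydrogen would still match on a core carrying methylsulfanyl or the extra methoxy.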